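Methyl to isopropyl on the aromatic ring of compound 3

This account rests on a few compounds, and the source may have more. Where it says the series, first, only, none or still open, it means among the compounds named here.

Compound 3 `Cc1ccccc1N1CCN(CCCNc2ncccc2C(=O)N(C)C)CC1` gives 2 nM in a functional assay for antagonist activity at Alpha-1A adrenergic receptor (Oryctolagus cuniculus) (on this read-out higher numbers stand for weaker binding and lower numbers for tighter binding), the largest of the three numbers measured, although its separation from compound 1 is within the scatter. Compound 1 `CN(C)C(=O)c1cccnc1NCCCN1CCN(c2ccccc2-c2ccccc2)CC1` gives 1.26 nM and compound 2 `CN(C)C(=O)c1cccnc1NCCCN1CCN(c2ccccc2-c2ncco2)CC1` gives 0.316 nM. The step of a 1.6-fold higher number from compound 1 to compound 3 (0.20 log units; within the scatter) stays within the scatter, while the steps of a 4.0-fold lower number from compound 1 to compound 2 (0.60 log units; beyond the scatter) and a 6.3-fold higher number from compound 2 to compound 3 (0.80 log units; beyond the scatter) lie beyond it. Compound 4 `CC(C)c1ccccc1N1CCN(CCCNc2ncccc2C(=O)N(C)C)CC1` differs from compound 3 by isopropyl in place of methyl on an aromatic carbon. Going by the values given here, the measured step that bears on this change is a 1.6-fold higher number from compound 1 to compound 3 (0.20 log units; within the scatter), where a large group and a small one at the same place gave numbers within the scatter of each other; no measured step covers isopropyl itself. On that basis the move from methyl to isopropyl is expected to produce no step beyond the scatter, in either direction. For compound 4 the estimate is 2 nM, with a range from 0.8 nM to 5 nM. That estimate means no change at the digits printed from compound 3 to compound 4 (within the scatter), expected to remain within the usual scatter.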

Compound 4, dissociation constant: 0.398 nM
For compound 4 the middle estimate is 5.0-fold (0.70 log units) above the measured one, outside the stated range (below it).
By their numbers in this assay, from the lowest: compounds 2 and 4 (each within the scatter of the next); then compounds 1 and 3 (each within the scatter of the next).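

On this aromatic carbon, ortho to a large group, a 5.0-fold lower number from compound 3 to compound 4 (0.70 log units; beyond the scatter) in this assay shows that a group with no ring and no hydrogen-bond acceptors can move the number beyond the scatter. The earlier compounds shown here showed such a move only with 1,3-oxazol-2-yl, and a 1.3-fold higher number from compound 2 to compound 4 (0.10 log units; within the scatter) leaves isopropyl and that group inseparable. The number also does not follow heavy-atom count alone: methyl and phenyl stand within the scatter of each other, yet a 3.2-fold lower number from compound 1 to compound 4 (0.50 log units; beyond the scatter) separates isopropyl from phenyl as well.

Nothing available here explains why isopropyl differs from methyl at this position. As far as these compounds go, whether ethyl, tert-butyl or cyclopropyl on this carbon would follow isopropyl or methyl remains open, as does the effect of a methoxy group there.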